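This account rests on a few compounds, and the source may have more. Where it says the series, first, only, none or still open, it means among the compounds named here.

Measured so far:
- compound 1 `Nc1ccccc1NC(=O)/C=C/c1ccc(CSc2cccc(F)c2)cc1`: 18.6%
- compound 2 `CCc1ccc(SCc2ccc(/C=C/C(=O)Nc3ccccc3N)cc2)cc1`: 20.9%

In a functional assay on HeLa cells (Homo sapiens) for inhibition, read by CCK-8 assay, with a stated time of 72 h, tested at 8 uM (a lower number here means less inhibition of growth, a higher number more inhibition of growth at the concentration tested), compound 2 gives 20.9% and compound 1 gives 18.6%, two values that lie within the scatter of each other. The next compound is compound 3 `Cc1ccc(SCc2ccc(/C=C/C(=O)Nc3ccccc3N)cc2)cc1`, which differs from compound 2 as follows: hydrogen in place of methyl on a saturated chain carbon bound to an aromatic carbon. This turns the 4-ethylphenyl into a 4-methylphenyl. Among the compounds with values here, only one measured step bears on this change: a number 2.3 percentage points higher from compound 1 to compound 2 (within the scatter). That step replaced 3-fluorophenyl on the sulfur with 4-ethylphenyl, a larger change than the one at hand, and it stayed within the scatter. No step beyond the scatter is therefore expected in this assay, and no direction can be favoured. The expected step is a number 0.9 percentage points lower from compound 2 to compound 3 (within the scatter). For compound 3 the estimate is 20%, with an expected range from 10% to 31%.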

Compound 3, percent growth inhibition at one concentration: 21.7%
Compound 3: middle estimate off by 1.7 percentage points, on the low side; the measured number falls inside the stated range.
By their numbers in this assay, from the lowest: compounds 1, 2 and 3 (each within the scatter of the next).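

In this assay, hydrogen in place of methyl on a saturated chain carbon bound to an aromatic carbon gives a number 0.8 percentage points higher from compound 2 to compound 3 (within the scatter), so trimming the 4-ethylphenyl to a 4-methylphenyl does not move the read-out beyond the scatter. The comparison with the 3-fluorophenyl compound gives a number 3.1 percentage points higher from compound 1 to compound 3 (within the scatter), which means that all three groups on the sulfur now lie within the scatter of one another, and this single concentration does not separate them. Nothing available offers an explanation for this result.

From the compounds shown here alone, it remains open whether a longer chain in place of the ethyl, or an amine or a carboxylic acid on the same ring, would produce a step beyond the scatter. Going by these compounds, whether these three compounds would also stay together at other concentrations is equally open.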